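A few compounds are considered here, and "the series" means these few. Any claim that something is new, unique, unknown or untested is made for them only; others in the source may bear on it.

Compound 3 `Fc1ccccc1Cn1nc(-c2ncccn2)c2cccnc21` gives 1250 nM in a functional assay (aorta) with Oryctolagus cuniculus as the target (on this read-out higher numbers stand for weaker inhibition and lower numbers for stronger inhibition), and stands at the top of the two single numbers in this set, although it is separated from its nearest neighbour only by a step within the scatter; compound 2 `Cc1nc(-c2nn(Cc3ccccc3F)c3ncccc23)oc1CO` gives 900 nM, while compound 1 `OCc1ccc(-c2nn(Cc3ccccc3F)c3ncccc23)o1` is recorded twice at 1700 nM; 1700 nM (2 entries). Going by the values given here, the one measured single-point step, a 1.4-fold higher number from compound 2 to compound 3 (0.14 log units; within the scatter), exchanged one aromatic heterocycle for another on the same carbon and stayed within the scatter. Compound 4 `Fc1ccccc1Cn1nc(-c2cc[nH]n2)c2cccnc21` differs from compound 3 by 1H-pyrazol-3-yl in place of pyrimidin-2-yl on an aromatic carbon, once more a swap of one small aromatic heterocycle for another at the same place. Among the compounds with values here, no measured pair shows this exact exchange, so the step from compound 2 to compound 3 is the only guide, and it suggests that such a swap need not move the number beyond the scatter. In this assay compound 4 is therefore expected to give about 1200 nM, within a range from 400 nM to 4000 nM. The expected step of a 1.0-fold lower number from compound 3 to compound 4 (0.02 log units; within the scatter) is accordingly estimated to be essentially flat.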

Compound 4, half-maximal inhibitory concentration: 1800 nM
Estimate against measurement, compound 4: 1.5-fold (0.18 log units) below; low and high end bracket the measured number.
By their numbers in this assay, from the lowest: compounds 2, 3 and 4 (each within the scatter of the next).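

Compound 4 shows that this carbon, next to the ring nitrogen, can carry a five-membered ring with a hydrogen-bond donor instead of a six-membered ring without one, and the number stays within the scatter in this assay (a 1.4-fold higher number from compound 3 to compound 4 (0.16 log units; within the scatter)). The comparison with the substituted oxazole also remains within the scatter (a 2.0-fold higher number from compound 2 to compound 4 (0.30 log units; within the scatter)), so compounds 2, 3 and 4 are not separated by these exchanges. No independent measurement is available to explain this result.

In compound 4, ring size and the hydrogen-bond donor change together, so the contribution of each remains unresolved. It also remains open whether a different kind of group at this carbon, such as an amine or a carboxylic acid, would move the number beyond the scatter, as none of the steps shown does.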